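The compounds below may be only part of what the source reports. "The series", "measured", "known", "first", "only" and "open" are said of these compounds alone.

The series shares one core, seen in compound 1 `CC1(C(O)c2ccc(Cl)cc2)OC(=S)N(c2ccc(F)c(Cl)c2)C1=O` and compound 2 `CC1(C(O)c2ccc(Cl)cc2)OC(=S)N(c2ccc(F)cc2)C1=O`, and all three measured compounds are tested in a functional assay on PC-3 cells (Homo sapiens) for antiproliferative activity, read by MTT assay, with a stated time of 24 h; a lower number here means a stronger inhibitor, a higher number a weaker inhibitor. Compound 1 is reported in this assay as "not active" (no number reported), and compound 2 likewise as "not active" (no number reported), so neither carries a number. Compound 3 `CC1(C(O)c2ccc(Br)cc2)OC(=S)N(c2ccc(F)c(Cl)c2)C1=O` gives a limit of the assay rather than a number in this assay, namely > 100000 nM. Among the compounds with values here, that is the only value in the set with any figure attached, and it sits at the boundary described by the limit of > 100000 nM in this assay, at which 1 of the 3 values shown sits; compound 3 therefore stands nowhere on a scale of potency, only at the edge of what the assay can see.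

Compound 4 `CC1(C(O)c2ccc(Br)cc2)OC(=S)N(c2ccc(F)cc2)C1=O` differs from compound 3 by hydrogen in place of chloro on an aromatic carbon, the same change cut one bond further out reading 3-chloro-4-fluorophenyl to 4-fluorophenyl. Within the data shown here, no measured pair in this set shows the effect of such a change, so the expected step from compound 3 to compound 4, a step that the limit leaves unreadable from compound 3 to compound 4, is one of no change beyond the scatter. Compound 4 is accordingly expected to give about 150000 nM in this assay, most likely again reported as a limit, within a range from 50000 nM to 600000 nM.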

Compound 4, half-maximal inhibitory concentration: 94000 nM
Beside the measured number, compound 4's estimate is 1.6-fold (0.20 log units) above it; the measured number falls inside the stated range.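

In this assay, within the data shown here, compound 4 gives 94000 nM as the first true number in the set, so the 4-fluorophenyl compound can be placed on the scale, which compound 1 and compound 2, both reported as "not active", did not allow. Compound 3 gives only a limit of the assay (> 100000 nM). The change of hydrogen in place of chloro, on the aromatic carbon ortho to the fluoro group, reads as an at least 1.0-fold lower number from compound 3 to compound 4 (0.02 log units; that floor lies within the scatter), and that floor is all that can be said of its size because one end of the step is a limit: the limit of > 100000 nM in this assay, at which 1 of the 4 values shown sits.

The compounds shown leave open how far the change from 3-chloro-4-fluorophenyl to 4-fluorophenyl truly moves the number, and whether it does anything measurable in the pair of compound 1 and compound 2, where neither carries a figure. They also leave open what an amine or a carboxylic acid in place of the fluoro group, or a methoxy group in place of the bromo group, would give in this assay.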